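Adding trifluoromethoxy to compound 3

The source may report more compounds than this note shows. Statements on the series, on what has been measured and on what is new or still open speak of the compounds shown alone.

Compound 1 `O=C(Nc1ccc(OC(F)(F)F)cc1)c1cc(F)ccc1O` — 810 nM
Compound 2 `O=C(Nc1ccc(C(F)(F)F)cc1)c1cc(F)ccc1O` — 580 nM
Compound 3 `O=C(Nc1ccccc1)c1cc(F)ccc1O` — "not determined" (no result reported)

These entries come from a functional assay on Jurkat cells (Homo sapiens) for cytotoxicity, read by luminescence and CellTiter-Glo, with a stated time of 3 days (a lower number here means a stronger inhibitor, a higher number a weaker inhibitor), and only the first two are numbers. Compound 3 stands nowhere on the scale, since its entry reads "not determined" (no result reported) and gives no starting point.

Compound 4 `O=C(Nc1cccc(OC(F)(F)F)c1)c1cc(F)ccc1O` arises from compound 3 by a single change (trifluoromethoxy in place of hydrogen on an aromatic carbon), which is trifluoromethoxy in place of hydrogen on an aromatic carbon, meta to a large group. Among the compounds with values here, no measured step covers this change, and none could without a number for compound 3. Within the data shown here, the only step available is a 1.4-fold lower number from compound 1 to compound 2 (0.15 log units; within the scatter) and it bears on the question only loosely. That step exchanges one group for another and says nothing about replacing a hydrogen. No size or direction can therefore be expected for the step itself.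

The closest guide is that compound 4 carries the same trifluoromethoxy group as compound 1, though at another place on the ring, and compound 1 gives 810 nM as its value. The estimate leans on that value and stays wide. In this assay the expected value for compound 4 is 700 nM with an estimated range from 250 nM to 2000 nM around it.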

Compound 4, half-maximal inhibitory concentration: 700 nM
Compound 4: the middle estimate sits on the measured number at the digits printed; low and high end bracket the measured number.
By their numbers in this assay, from the lowest: compounds 2, 4 and 1 (each within the scatter of the next).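

No new step can be read from compound 4, as compound 3, its partner by a single change, carries no number in this assay to compare it with. No measured evidence accounts for the value of compound 4. The compounds shown leave open how far, and in which direction, trifluoromethoxy in place of hydrogen on an aromatic carbon moves the number in this assay for this series.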